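Replacing Isobutyl with a Larger Saturated Ring Group

This account rests on a few compounds, and the source may have more. Where it says the series, first, only, none or still open, it means among the compounds named here.

Compound 1 `CC(C)Cn1nc(C(=O)N[C@H]2COc3ccccc3N(C)C2=S)nc1Cc1ccccc1` was tested in a functional assay on HT-29 cells (Homo sapiens) for inhibition, read by luminescence and CellTiter-Glo, with a stated time of 24 h (on this read-out lower numbers stand for an effect already at smaller amounts and higher numbers for an effect only at larger amounts of compound), where compound 1 gives 1230 nM, the lowest number of the three shown, with compound 2 within the usual scatter of it. Compound 2 `CN1C(=S)[C@@H](NC(=O)c2nc(Cc3ccccc3)n(CCC(F)(F)F)n2)COc2ccccc21` gives 1550 nM and compound 3 `CN1C(=S)[C@@H](NC(=O)c2nc(Cc3ccccc3)n(CC3CCOC3)n2)COc2ccccc21` gives 4420 nM. Compound 4 `CN1C(=S)[C@@H](NC(=O)c2nc(Cc3ccccc3)n(C3CCN(C(=O)OC(C)(C)C)C3)n2)COc2ccccc21` has not been measured; it differs from compound 1 in this way: a group of 12 heavy atoms (9 carbon, 1 nitrogen, 2 oxygen; one five-membered non-aromatic ring with 1 hetero atom) in place of a group of 4 heavy atoms (4 carbon; no ring), on an aromatic nitrogen. The measured steps that bear on this are a 1.3-fold higher number from compound 1 to compound 2 (0.10 log units; within the scatter), a 3.6-fold higher number from compound 1 to compound 3 (0.56 log units; beyond the scatter) and a 2.9-fold higher number from compound 2 to compound 3 (0.46 log units; beyond the scatter). A modest rise is expected for compound 4 because a 3.6-fold higher number from compound 1 to compound 3 (0.56 log units; beyond the scatter) also placed a five-membered non-aromatic ring on that nitrogen, and the entering group here is larger still. For compound 4 the expected value is 4000 nM, with a range from 1500 nM to 12000 nM, an estimated step of a 3.3-fold higher number from compound 1 to compound 4 (0.51 log units; beyond the scatter).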

Compound 4, half-maximal effective concentration: > 10000 nM
Compound 4: a limit, no number; the forecaster's own chance of this, stated with the estimate: 10%; at least 2.5-fold (0.39 log units) between middle value and limit.
By their numbers in this assay, from the lowest: compounds 1 and 2 (each within the scatter of the next); then compound 3. At a limit, above all of these: compound 4.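

Compound 4 gives only a limit, not a number: the limit of > 10000 nM in this assay, at which 1 of the 4 values shown sits.

Even so, the steps can be read as lower bounds: an at least 8.1-fold higher number from compound 1 to compound 4 (0.91 log units; beyond the scatter) and an at least 6.4-fold higher number from compound 2 to compound 4 (0.80 log units; beyond the scatter) show that this aromatic nitrogen does not take every group equally well. Compound 3 already carries a five-membered non-aromatic ring there, yet an at least 2.2-fold higher number from compound 3 to compound 4 (0.35 log units; beyond the scatter) shows that having such a ring does not set the number alone.

Going by these compounds, how far compound 4 lies past its limit stays open, as does whether its heavy-atom count or its hydrogen-bond acceptors matter. A plain amine or a longer alkyl chain on this nitrogen could help separate these.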